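A Two-Oxygen Ring Gives Way to Phenyl

The compounds below may be only part of what the source reports. "The series", "measured", "known", "first", "only" and "open" are said of these compounds alone.

Compound 1 `Cc1cc(C)c(S(=O)(=O)N2CCC(C3OCC(C)CO3)CC2)c(C)c1` gives > 5000 nM.
Compound 2 `CC1CCN(C2CCN(S(=O)(=O)c3cccc(-c4ccccc4F)c3)CC2)CC1` gives 10 nM.
Compound 3 `CC1CCN(C2CCN(S(=O)(=O)c3cccc4ccccc34)CC2)CC1` gives 0.65 nM.

All three were tested in a functional assay on DLD-1 cells (Homo sapiens) for antiproliferative activity, read by CellTiter-Glo, with a stated time of 72 h; on this read-out higher numbers stand for weaker inhibition and lower numbers for stronger inhibition. For compound 1 the result is not a number but a limit of the assay, (the limit of > 5000 nM in this assay, at which 1 of the 3 values shown sits), so compound 1 stands at the weak end of what was measured. Compound 2 and compound 3 return real numbers well inside the range, but each of them differs from compound 1 in several places at once, so their values only show that strong inhibition is reachable within this series, not which part of compound 1 holds it back.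

Compound 4 `Cc1cc(C)c(S(=O)(=O)N2CCC(c3ccccc3)CC2)c(C)c1` keeps the core of compound 1 and changes one place: a group of 6 heavy atoms (6 carbon; one six-membered aromatic ring of carbon only) in place of a group of 7 heavy atoms (5 carbon, 2 oxygen; one six-membered non-aromatic ring with 2 hetero atoms), on a saturated ring carbon. Among the compounds with values here, no measured pair in this set isolates that change, so the size of the step is open. With compound 1 at the limit, the estimated step is an at least 1.2-fold lower number from compound 1 to compound 4 (0.09 log units; that floor lies within the scatter), modest and toward stronger inhibition if anything, though not necessarily beyond the scatter. Compound 4 is therefore expected to give about 4000 nM, likely between 800 nM and 20000 nM, with a fair chance that this assay again reports only a limit.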

Compound 4, half-maximal inhibitory concentration: > 5000 nM
Compound 4 ended at the assay's limit; the forecaster's own chance of this, stated with the estimate: 60%; middle value at least 1.2-fold (0.09 log units) away from the limit.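

In this assay compound 4 gives > 5000 nM, which is a limit and not a number. Compound 1 sits at the same limit, so no step can be read between compound 1 and compound 4: the limit of > 5000 nM in this assay, at which 2 of the 4 values shown sit.

Left open is whether phenyl in place of the two-oxygen ring changes inhibition at all, and which part of compound 1 holds it back.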